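Working notes: amine end of the diaryl ether series

This account rests on a few compounds, and the source may have more. Where it says the series, first, only, none or still open, it means among the compounds named here.

Measured so far in a functional assay on DLD-1 cells (Homo sapiens) for inhibition, read by MTT assay, with a stated time of 72 h; on this read-out higher numbers stand for weaker inhibition and lower numbers for stronger inhibition:
compound 1 `COc1cc(Oc2cccc(Nc3ccccc3)c2)cc(OC)c1CNCCNC(C)=O` gives 6010 nM
compound 2 `COc1ccc(CCCNCc2c(OC)cc(Oc3cccc(Nc4ccccc4)c3)cc2OC)cc1` gives 2540 nM
compound 3 `COc1cc(Oc2cccc(Nc3ccccc3)c2)cc(OC)c1CNC(C)C` gives > 20000 nM, which is a limit of the assay and not a number the limit of > 20000 nM in this assay, at which 1 of the 3 values shown sits.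

Compound 3 stands at the weak end of the three. The two steps that lead to it both read weaker: an at least 3.3-fold higher number from compound 1 to compound 3 (0.52 log units; beyond the scatter) and an at least 7.8-fold higher number from compound 2 to compound 3 (0.89 log units; beyond the scatter). Between the two compounds with a number, the step of a 2.4-fold lower number from compound 1 to compound 2 (0.37 log units; beyond the scatter) shows the longer 3-(4-methoxyphenyl)propyl chain on the amine nitrogen reading stronger than the 2-acetamidoethyl chain.

Compound 4 `COc1cc(Oc2cccc(Nc3ccccc3)c2)cc(OC)c1CN(C)C` differs from compound 3 by dimethylamino in place of isopropylamino on a saturated chain carbon bound to an aromatic carbon. Within the data shown here, no measured step covers this change directly. What bears on it is the pair of steps ending at compound 3: each time the substituent on that amine nitrogen was shortened to isopropyl, this assay read at least modestly weaker, down to the limit. Compound 4 shortens the amine end once more, to dimethylamino, and removes the hydrogen-bond donor counted above. The expectation is therefore that compound 4 stays at the limit: no step beyond the scatter, a step that the limit leaves unreadable from compound 3 to compound 4. Compound 4 is estimated at 30000 nM, within 10000 nM to 100000 nM, with a real chance that only a limit is reported again.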

Compound 4, half-maximal inhibitory concentration: > 20000 nM
Compound 4 was reported as a limit; the forecaster's own chance of this, stated with the estimate: 70%; the middle value is on the limit's open side.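

In this assay compound 4 gives > 20000 nM, which is a limit of the assay and not a number, and compound 3 reads the same way: the limit of > 20000 nM in this assay, at which 2 of the 4 values shown sit. The readable steps are an at least 7.8-fold higher number from compound 2 to compound 4 (0.89 log units; beyond the scatter) and an at least 3.3-fold higher number from compound 1 to compound 4 (0.52 log units; beyond the scatter), so among these four compounds the two longer substituents on the amine nitrogen read stronger than both short amine ends, whether the short end keeps its hydrogen-bond donor, as isopropylamino does, or has none, as dimethylamino does. The step from isopropylamino to dimethylamino cannot be read, with both compounds at the limit, so any effect of that change on this read-out stays hidden.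

As far as these compounds go, how far compound 3 and compound 4 lie beyond the limit remains open, as does whether chain length or the end group of the longer chains goes with the stronger reading. A plain butylamino or a 3-phenylpropylamino group at this position would help separate length from the acetamido and 4-methoxyphenyl ends.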